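The compounds below may be only part of what the source reports. "The series", "measured", "known", "first", "only" and "open" are said of these compounds alone.

Measured in an in vitro ADME assay on microsomes from liver (Homo sapiens) for pharmacokinetics, read by LC-MS; a higher number here means faster removal of the compound, a lower number slower removal:
- compound 1 `Cc1cccc2c1nc(C)n2-c1ccc(C(=O)NC2CC2)s1`: 10 mL/min/kg
- compound 2 `COc1cccc2c1nc(C)n2-c1ccc(C(=O)NC2CC2)s1`: 4 mL/min/kg
- compound 3 `Cc1nc2c(F)cccc2n1-c1ccc(C(=O)NC2CC2)s1`: < 4 mL/min/kg

Compound 3 has no exact number, only a limit: it stands at the limit of < 4 mL/min/kg in this assay, at which 1 of the 3 values shown sits.

Compound 4 `Cc1nc2c(Cl)cccc2n1-c1ccc(C(=O)NC2CC2)s1` has chloro in place of fluoro on an aromatic carbon. Among the compounds with values here, no compound with chloro has been measured, so the expectation has to come from the three neighbouring steps.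

Methoxy in place of methyl gives a 2.5-fold lower number from compound 1 to compound 2 (0.40 log units; beyond the scatter). Fluoro in place of methyl gives an at least 2.5-fold lower number from compound 1 to compound 3 (0.39 log units; beyond the scatter). Fluoro in place of methoxy gives a number no higher from compound 2 to compound 3 (the limit leaves the size open).

So both replacements of methyl moved the number down by a modest amount, and the step between methoxy and fluoro cannot be sized. Chloro is expected to fall within the span these compounds mark out, nearer to compound 2, with 4 mL/min/kg, than to compound 1, with 10 mL/min/kg.

A small upward move is therefore expected, estimated as an at least 1.2-fold higher number from compound 3 to compound 4 (0.09 log units; that floor lies within the scatter).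

For compound 4 the estimated value in this assay is 5 mL/min/kg, with an expected range of 3 mL/min/kg to 10 mL/min/kg.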

Compound 4, clearance: < 4 mL/min/kg
Compound 4 was reported as a limit; the forecaster's own chance of this, stated with the estimate: 35%; middle value at least 1.2-fold (0.09 log units) from the limit.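

Compound 4 gives < 4 mL/min/kg in this assay and that value is a limit, not a number. Chloro in place of methyl gives an at least 2.5-fold lower number from compound 1 to compound 4 (0.39 log units; beyond the scatter) and so makes it the third replacement of the methyl on this aromatic carbon, after methoxy and fluoro, to lower the number; none of the compounds shown goes against this. Chloro in place of methoxy gives a number no higher from compound 2 to compound 4 (the limit leaves the size open). The step from compound 3 to compound 4 cannot be read, and fluoro and chloro cannot be ranked at this position because compound 3 and compound 4 share the same reported limit: the limit of < 4 mL/min/kg in this assay, at which 2 of the 4 values shown sit.

As far as these compounds go, how far compound 3 and compound 4 actually lie under that limit stays open, and so does any real difference between them or between either of them and the methoxy of compound 2. Also open, from the compounds shown here alone, is whether other groups on this same aromatic carbon, such as trifluoromethyl, a nitrile or an amine, would keep the number as low as chloro and fluoro do.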